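The source may report more compounds than this note shows. Statements on the series, on what has been measured and on what is new or still open speak of the compounds shown alone.

Three compounds have been measured in a functional assay on MDA-MB-231 cells (Homo sapiens) for cytotoxicity, read by MTT assay, with a stated time of 48 h; a higher number here means a weaker inhibitor, a lower number a stronger inhibitor:

- compound 1 `O=C(/C=C/c1ccc2c(c1)B(O)OC2)c1ccccc1`: 2300 nM
- compound 2 `O=C(/C=C/c1ccc2c(c1)B(O)OC2)c1ccc(Cl)cc1`: 7900 nM
- compound 3 `O=C(/C=C/c1ccc2c(c1)B(O)OC2)c1ccc(Br)cc1`: 9500 nM

Compound 1 has the lowest number of the three. Its nearest neighbour is compound 2, a step of a 3.4-fold higher number from compound 1 to compound 2 (0.54 log units; beyond the scatter); the furthest is compound 3, a step of a 4.1-fold higher number from compound 1 to compound 3 (0.62 log units; beyond the scatter). Both of those steps are beyond the scatter but modest in size. Between the two halogen compounds the gap is small: a 1.2-fold higher number from compound 2 to compound 3 (0.08 log units; within the scatter), which is within the scatter.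

Compound 4 `O=C(/C=C/c1ccc2c(c1)B(O)OC2)c1ccc(I)cc1` has not yet been measured. It differs from compound 1 by iodo in place of hydrogen on an aromatic carbon. The two steps that bear on this change are the chloro and bromo steps from compound 1, which moved the number up by a modest and similar amount. A third halogen in the same place is therefore expected to give a modest rise as well, so compound 4 is expected to show a 4.8-fold higher number from compound 1 to compound 4 (0.68 log units; beyond the scatter). The estimate for compound 4 is 11000 nM, with a range from 5000 nM to 25000 nM.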

Compound 4, half-maximal inhibitory concentration: 14900 nM
Compound 4: the middle estimate sits 1.4-fold (0.13 log units) below what was measured; the measured number falls inside the stated range.
By their numbers in this assay, from the lowest: compound 1; then compounds 2, 3 and 4 (each within the scatter of the next).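

In this assay the change from phenyl to 4-iodophenyl gives a 6.5-fold higher number from compound 1 to compound 4 (0.81 log units; beyond the scatter) and makes iodo the third halogen at this place, para to a large group, to raise the number from that of compound 1 by a step beyond the scatter. The further steps a 1.6-fold higher number from compound 3 to compound 4 (0.20 log units; within the scatter) and a 1.9-fold higher number from compound 2 to compound 4 (0.28 log units; within the scatter) are both within the scatter, so no order can be drawn among the three halogens: what sets compounds 2, 3 and 4 apart from compound 1 is that a halogen is present, not which one. No measurement here explains why a halogen at this place gives a higher number.

Still open, from the compounds shown here alone, is how a group other than a halogen, such as an amine or a carboxylic acid, would compare with hydrogen at this place. Also open, going by these compounds, is whether iodo on another carbon of this ring would give a similar step.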